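A 3-methoxyphenyl swap on a level pair

The compounds below may be only part of what the source reports. "The series", "measured", "known", "first", "only" and "open" are said of these compounds alone.

In a functional assay on A549 cells (Homo sapiens) for antiproliferative activity, read by MTT assay, with a stated time of 72 h (on this read-out higher numbers stand for weaker inhibition and lower numbers for stronger inhibition), compound 1 `NC1CCc2nc(-c3ccncc3)nc(Nc3cccc(F)c3)c2C1` gives 19400 nM and compound 2 `CN(C)c1ccc(Nc2nc(-c3ccncc3)nc3c2CC(N)CC3)cc1` gives 17100 nM. Going by the values given here, the only measured step, a 1.1-fold lower number from compound 1 to compound 2 (0.05 log units; within the scatter), puts 4-(dimethylamino)phenyl in place of 3-fluorophenyl on a nitrogen on an aromatic ring, and it stays within the scatter of repeated measurements. Compound 2 therefore stands level with compound 1. Compound 3 `COc1cccc(Nc2nc(-c3ccncc3)nc3c2CC(N)CC3)c1` keeps the shared core and changes the group at that same place: 3-methoxyphenyl in place of 4-(dimethylamino)phenyl on a nitrogen on an aromatic ring. Among the compounds with values here, a single step is thin evidence, but it is the only guide here, and it shows no change beyond the scatter. Resting on a 1.1-fold lower number from compound 1 to compound 2 (0.05 log units; within the scatter), no shift beyond the scatter is expected in this assay. The expected step is small: a 1.1-fold higher number from compound 2 to compound 3 (0.02 log units; within the scatter). For compound 3 the estimated value is 18000 nM, with an expected range from 8000 nM to 38000 nM.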

Compound 3, half-maximal inhibitory concentration: 18000 nM
The estimate for compound 3 equals the measured number at the digits printed; the range from low to high includes it.
By their numbers in this assay, from the lowest: compounds 2, 3 and 1 (each within the scatter of the next).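

In this assay the group on a nitrogen on an aromatic ring now comes in three forms, and putting 3-methoxyphenyl in place of 4-(dimethylamino)phenyl gives a 1.1-fold higher number from compound 2 to compound 3 (0.02 log units; within the scatter) as its result. Exchanging fluoro for methoxy on an aromatic carbon, the smaller change, gives a 1.1-fold lower number from compound 1 to compound 3 (0.03 log units; within the scatter) as its result, so across these three substituted phenyl groups the number does not move beyond the scatter. Nothing measured here explains why these swaps leave the number level.

As far as these compounds go, all three compounds carry a substituted phenyl group at this place, so a longer alkyl chain or a phenyl group bearing a carboxylic acid remains untested here. The amine on the shared core is also the same throughout, which leaves its part in the activity unknown.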